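The compounds below may be only part of what the source reports. "The series", "measured", "known", "first", "only" and "open" are said of these compounds alone.

Compound 1 `COc1ccc(-c2cnc(NC(=O)c3ncc[nH]3)n2C)cc1` gives > 100000 nM
Compound 2 `COc1ccc(-c2cnc(NC(=O)c3ccccc3O)n2C)cc1` gives > 100000 nM
Compound 3 `COc1ccc(-c2nc3ncc(-c4ccc(F)cc4)cc3[nH]2)cc1` gives > 100000 nM

All three compounds were tested in a toxicity assay on THP-1 cells (Homo sapiens) for inhibition; a lower number here means that less compound is tolerated, a higher number that more compound is tolerated. Compound 2 stands at > 100000 nM, which is a limit of the assay and not a number. Compound 2 is not alone there, as the data show (the limit of > 100000 nM in this assay, at which 3 of the 3 values shown sit).

Compound 4 `COc1ccc(-c2cnc(NC(=O)C3CCNCC3)n2C)cc1` keeps the rest of compound 2 and changes one group: piperidin-4-yl in place of 2-hydroxyphenyl on a carbonyl carbon. Among the measured compounds shown here, the only measured step at this carbonyl carbon is a step that the two limits leave unreadable from compound 1 to compound 2, so it offers no size to carry over. For the measured compounds named here, compound 3 differs from the others in more than one place and adds no step. With no readable step to build on, no change beyond the usual scatter is expected, and no direction can be given. The expected step is a number no higher from compound 2 to compound 4 (the limit leaves the size open). For compound 4 the estimated value is 100000 nM, with an expected range from 30000 nM to 200000 nM.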

Compound 4, half-maximal cytotoxic concentration: > 100000 nM
Compound 4: no number, only a limit (the forecaster's own chance of this, stated with the estimate: 75%); the middle value sits exactly at the limit.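

Among the compounds shown here, no step from compound 1 or compound 2 to compound 4 can be read, since each of these results is a limit of the assay and not a number: the limit of > 100000 nM in this assay, at which 4 of the 4 values shown sit. The compounds shown leave open whether changing the group on this carbonyl carbon alters the result in this assay at all.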